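Purine piperazines: cyclopentyl replacing tosyl on the ring nitrogen

A few compounds are considered here, and "the series" means these few. Any claim that something is new, unique, unknown or untested is made for them only; others in the source may bear on it.

Measured so far:
compound 1, `FC(F)(F)c1ccc(N2CCN(c3ncnc4[nH]cnc34)CC2)cc1`, in a functional assay on T47D cells (Homo sapiens) for cytotoxicity, read by sulforhodamine B assay, with a stated time of 72 h (on this read-out higher numbers stand for weaker inhibition and lower numbers for stronger inhibition), gives 39400 nM
compound 2, `Cc1ccc(S(=O)(=O)n2cnc3c(N4CCN(c5ccc(C(F)(F)F)cc5)CC4)ncnc32)cc1`, in this assay gives 42700 nM

Both numbers sit at the weak end of what this assay resolves. Within the data shown here, compound 2 is not separated from compound 1: the only step in the set, a 1.1-fold higher number from compound 1 to compound 2 (0.03 log units; within the scatter), is within the scatter, so the two compounds stand together and neither can be called the weaker.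

Compound 3, `FC(F)(F)c1ccc(N2CCN(c3ncnc4c3ncn4C3CCCC3)CC2)cc1`, has not been measured. It differs from compound 2 by cyclopentyl in place of (4-methylphenyl)sulfonyl on an aromatic nitrogen. Among the measured compounds shown here, the one step that bears on it is the step from compound 1 to compound 2, where a group was put on the same aromatic nitrogen without any shift in the number beyond the scatter. For the measured compounds named here, no measured compound carries a cyclopentyl, so nothing in the set speaks for or against that group in particular. On the evidence of the step from compound 1 to compound 2 alone, the expected step of a 1.2-fold lower number from compound 2 to compound 3 (0.09 log units; within the scatter) is none beyond the scatter. Compound 3 is therefore estimated at 35000 nM, with a range of 10000 nM to 120000 nM.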

Compound 3, half-maximal inhibitory concentration: < 100 nM
Compound 3 was reported as a limit; the forecaster's own chance of this, stated with the estimate: 15%; at least 350-fold (2.54 log units) between middle value and limit.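

The aromatic nitrogen of the five-membered ring is a position that strongly affects the number in this assay, which a 1.1-fold higher number from compound 1 to compound 2 (0.03 log units; within the scatter) did not show. Cyclopentyl in place of (4-methylphenyl)sulfonyl gives an at least 420-fold lower number from compound 2 to compound 3 (2.63 log units; beyond the scatter), and cyclopentyl in place of hydrogen gives an at least 390-fold lower number from compound 1 to compound 3 (2.59 log units; beyond the scatter), so among the three groups shown on this nitrogen, only cyclopentyl separates from the others, and putting just any group there does not produce the shift. Compound 3 stands at a limit and not at a number: the limit of < 100 nM in this assay, at which 1 of the 3 values shown sits.

The compounds shown leave open whether the shift needs a carbon ring or only a plain carbon group, and a methyl, an isopropyl, a cyclohexyl or a phenyl on the same nitrogen would tell these apart. Also open, as far as these compounds go, are how far past its limit compound 3 really lies and whether the shift depends on the 4-trifluoromethylphenyl on the piperazine, which stays the same throughout, so that a chlorine or a methoxy in place of the trifluoromethyl remains an untested question for this series.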